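Swapping an Aryl Group for an Ester: Compound 3

A few compounds are considered here, and "the series" means these few. Any claim that something is new, unique, unknown or untested is made for them only; others in the source may bear on it.

Of the compounds shown here, two built on one shared core have been tested in an ADME assay on HeLa cells (Homo sapiens) for cytotoxicity, read by sulforhodamine B assay, with a stated time of 48 h, tested at 10 uM; a higher number here means more inhibition at the concentration tested (going by the name of the read-out), a lower number less inhibition. Compound 1 `COc1nc2ccc(Br)cc2cc1C(c1ccccc1)n1cc(-c2ccccc2)nn1` gives 13.9%. Compound 2 `COc1nc2ccc(Br)cc2cc1C(c1ccccc1)n1cc(-c2ccccc2F)nn1`, which carries a fluoro in place of hydrogen on an aromatic carbon, gives 14.1%. The step of a number 0.2 percentage points higher from compound 1 to compound 2 (within the scatter) lies within the scatter, so the two numbers cannot be told apart, and compound 2 is simply one of two closely matched compounds, neither of them strongly inhibiting at this concentration.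

Compound 3 `CCOC(=O)c1cn(C(c2ccccc2)c2cc3cc(Br)ccc3nc2OC)nn1` has not yet been measured. It differs from compound 2 by ethoxycarbonyl in place of 2-fluorophenyl on an aromatic carbon. Within the data shown here, no measured step bears directly on this change: the only step at hand, a number 0.2 percentage points higher from compound 1 to compound 2 (within the scatter), concerns fluoro in place of hydrogen on an aromatic carbon and stayed within the scatter. With so little to go on, compound 3 is expected to remain near the numbers seen so far, with a wide range to allow for an untested change. The estimated step of a number 0.1 percentage points lower from compound 2 to compound 3 (within the scatter) is expected to stay within the scatter. Compound 3 is estimated at 14%, with a range from 3% to 35%.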

Compound 3, a percentage reported as inhibition, at one concentration (the size of the read-out at that concentration, not a potency): -3.67%
Estimate against measurement, compound 3: 17.7 percentage points above; the whole stated range lies above it.
By their numbers in this assay, from the lowest: compound 3; then compounds 1 and 2 (each within the scatter of the next).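

In this assay, the aromatic carbon of the five-membered ring with 3 nitrogen now proves sensitive to what it carries, which the fluoro swap on the outer phenyl ring could not show. Ethoxycarbonyl in place of 2-fluorophenyl gives a number 17.8 percentage points lower from compound 2 to compound 3 (beyond the scatter), and ethoxycarbonyl in place of phenyl gives a number 17.6 percentage points lower from compound 1 to compound 3 (beyond the scatter), so the two comparisons agree and the change holds whether or not the departing ring carries fluoro. Nothing measured here explains why the number falls, as no separate measurement of any property of these groups is available.

This change removes an aromatic ring and brings in a carbonyl-containing ester with 2 hydrogen-bond acceptors in one move, so these compounds cannot say which part of the swap goes with the lower number. A plain butyl chain on the same carbon would keep the ring out without the ester, while a carboxylic acid or a primary amide there would show whether the result holds for other carbonyl groups.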